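The compounds below may be only part of what the source reports. "The series", "measured", "known", "first", "only" and "open" are said of these compounds alone.

In a functional assay (aorta) for inhibition, with Rattus norvegicus as the target (on this read-out lower numbers stand for stronger inhibition and higher numbers for weaker inhibition), compound 1 (`C/N=C(\S)[C@]1(c2cc(Cl)cc(Cl)c2)CCCC[S+]1[O-]`) gives 400 nM and compound 2 (`CC/N=C(\S)[C@]1(c2cccnc2)CCCC[S+]1[O-]`) gives 300 nM on the same read-out. Compound 3 (`CCCC/N=C(\S)[C@]1(c2cccnc2)CCCC[S+]1[O-]`) stands highest of the three at 8000 nM and is so far the weakest inhibitor. Compound 4 (`O=C(O)CC/N=C(\S)[C@]1(c2cccnc2)CCCC[S+]1[O-]`) differs from it by carboxy in place of ethyl on a saturated chain carbon, two bonds along the chain from a double-bonded nitrogen. Within the data shown here, the only measured step at this place is large (a 27-fold higher number from compound 2 to compound 3 (1.43 log units; beyond the scatter)), but it adds ethyl, not carboxy, so it gives no direction for this change. In this assay the expected step is therefore estimated as a 1.3-fold lower number from compound 3 to compound 4 (0.12 log units; within the scatter), with wide uncertainty. The estimate for compound 4 is 6000 nM within an expected range (800 nM to 40000 nM).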

Compound 4, concentration for 90% inhibition: > 30000 nM
Compound 4 ended at the assay's limit; the forecaster's own chance of this, stated with the estimate: 15%; at least 5.0-fold (0.69 log units) between middle value and limit.
By their numbers in this assay, from the lowest: compounds 2 and 1 (each within the scatter of the next); then compound 3. At a limit, above all of these: compound 4.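

Compound 4 stands at a limit of this assay, not at a true number: the limit of > 30000 nM in this assay, at which 1 of the 4 values shown sits. Even so, carboxy in place of ethyl on this saturated chain carbon gives an at least 3.7-fold higher number from compound 3 to compound 4 (0.57 log units; beyond the scatter), and carboxy in place of hydrogen gives an at least 100-fold higher number from compound 2 to compound 4 (2.00 log units; beyond the scatter). So ethyl is not the only addition here that raises the number, and carboxy raises it further than ethyl does. From the compounds shown here alone, how far compound 4 truly lies past its limit stays open. So does whether an amine or an ester at this place would behave like ethyl or like carboxy.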